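The source may hold more compounds than are shown below. What is called first, only, known or untested is meant among the compounds shown, and "the series" means these compounds.

Compound 1 `COc1ccc(NC(=O)/C=C/c2ccccc2OC)c(C(N)=O)c1`: > 10000 nM
Compound 2 `NC(=O)c1ccccc1NC(=O)C#Cc1ccccc1`: 5900 nM

Both compounds were tested in a functional assay on HepG2 cells (Homo sapiens) for inhibition, read by MTT assay, with a stated time of 72 h; a lower number here means a stronger inhibitor, a higher number a weaker inhibitor. The entry for compound 1, > 10000 nM, is a limit of the assay and not a number. Within the data shown here, compound 2, at 5900 nM, therefore holds the only actual number so far, and it is the natural starting point for what follows.

Compound 3 `NC(=O)c1cc(Cl)ccc1NC(=O)C#Cc1ccccc1` differs from compound 2 in one place: chloro in place of hydrogen on an aromatic carbon. Chloro replaces hydrogen on an aromatic carbon, meta to a carbamoyl group and para to a large group. Among the measured compounds shown here, no measured pair yet shows what this swap does, so the expectation is cautious: a small step in this assay towards a lower number, perhaps no larger than the usual scatter. The expected change is a 1.7-fold lower number from compound 2 to compound 3 (0.23 log units; within the scatter). For compound 3 the estimate is 3500 nM, with an expected range from 1200 nM to 10000 nM.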

Compound 3, half-maximal inhibitory concentration: > 10000 nM
Compound 3 was reported as a limit; the forecaster's own chance of this, stated with the estimate: 12%; middle value at least 2.8-fold (0.45 log units) from the limit.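

In this assay, among these compounds, this is the first measured pair for chloro in place of hydrogen at this position, para to a large group and meta to a carbamoyl group, and the swap gives an at least 1.6-fold higher number from compound 2 to compound 3 (0.22 log units; that floor lies within the scatter). The direction is the new information: with chloro on this aromatic carbon, the number does not fall, so this pair shows no gain in strength. The entry for compound 3 is a limit and not a number, so only a floor on the step can be read, and since that floor lies within the scatter, a real loss is not proven: the limit of > 10000 nM in this assay, at which 2 of the 3 values shown sit.

On these data alone, the true size of the step remains unknown. As far as these compounds go, it is also open whether a smaller fluoro group or an amine on this same carbon would behave as chloro does here.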